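Swapping one arm of a symmetric-looking core

This account rests on a few compounds, and the source may have more. Where it says the series, first, only, none or still open, it means among the compounds named here.

Compound 1 `C=CCn1c(=O)/c(=C\c2cccc(F)c2)[nH]c(=O)/c1=C\c1ccccc1OC` is the weakest of the three compounds measured here in a functional assay on A549 cells (Homo sapiens) for cytotoxicity, read by CCK-8 assay, with a stated time of 72 h (a higher number here means a weaker inhibitor, a lower number a stronger inhibitor), where compound 1 gives 19700 nM. Compound 2 `C=CCn1c(=O)/c(=C\c2ccccc2Cl)[nH]c(=O)/c1=C\c1ccccc1OC` gives 5300 nM in this assay, and compound 3 `C=CCn1c(=O)/c(=C\c2cccc(Cl)c2Cl)[nH]c(=O)/c1=C\c1ccccc1OC` gives 2300 nM. Both of those compounds differ from compound 1 at the same place as the change now under study: the step of a 3.7-fold lower number from compound 1 to compound 2 (0.57 log units; beyond the scatter) and the step of an 8.6-fold lower number from compound 1 to compound 3 (0.93 log units; beyond the scatter) each replaced the 3-fluorophenyl arm, and each brought the number down, with the further step a 2.3-fold lower number from compound 2 to compound 3 (0.36 log units; beyond the scatter) adding a little more. Compound 4 `C=CCn1c(=O)/c(=C\c2ccccc2OC)[nH]c(=O)/c1=C\c1ccccc1OC` is the unmeasured compound; it differs from compound 1 by 2-methoxyphenyl in place of 3-fluorophenyl on a double-bonded chain carbon bound to an aromatic carbon. Going by the values given here, no measured step used a methoxy-bearing group at this place, so the size of the effect is uncertain, but every replacement of the 3-fluorophenyl arm so far has lowered the number. A step of a 2.5-fold lower number from compound 1 to compound 4 (0.39 log units; beyond the scatter) is therefore expected, downward. Compound 4 is estimated at 8000 nM in this assay, within a range from 3000 nM to 25000 nM.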

Compound 4, half-maximal inhibitory concentration: 22400 nM
For compound 4 the middle estimate is 2.8-fold (0.45 log units) below the measured one, and the stated range covers the measured number.
By their numbers in this assay, from the lowest: compound 3; then compound 2; then compounds 1 and 4 (each within the scatter of the next).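

The earlier replacements of the 3-fluorophenyl arm all lowered the number, but 2-methoxyphenyl does not join them: in this assay the result is a 1.1-fold higher number from compound 1 to compound 4 (0.06 log units; within the scatter) and leaves these two arms level. Changing the group on the aromatic carbon from chloro to methoxy gives a 4.2-fold higher number from compound 2 to compound 4 (0.63 log units; beyond the scatter) and the wider swap of the whole arm gives a 9.7-fold higher number from compound 3 to compound 4 (0.99 log units; beyond the scatter). Among these four compounds the lower numbers go with the chloro-bearing arms of compound 2 and compound 3, not with any change of arm. Nothing available here explains this difference.

On these data alone, it remains open how a bromo or trifluoromethyl group on this arm would compare with chloro, and how an amine or a carboxylic acid would fare. The kind of group also remains tangled with where it sits, since 3-fluorophenyl and 2-chlorophenyl differ in both.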